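Substituent exchange at one ring position: compound 3 to compound 4

The source may report more compounds than this note shows. Statements on the series, on what has been measured and on what is new or still open speak of the compounds shown alone.

Measured so far in a functional assay on HeLa cells (Homo sapiens) for inhibition, read by sulforhodamine B assay, with a stated time of 48 h; on this read-out higher numbers stand for weaker inhibition of growth and lower numbers for stronger inhibition of growth:
- compound 1 `O=C(/C=C/c1c(Cl)nc2ccccn12)N1CCC=CS1(=O)=O`: 8200 nM
- compound 2 `COc1cccc(/C=C/C(=O)N2CCC=CS2(=O)=O)c1`: 23700 nM
- compound 3 `O=C(/C=C/c1cccc(-c2ccccc2)c1)N1CCC=CS1(=O)=O`: 19800 nM

On these three numbers compound 3 stands second highest; its nearest neighbour is compound 2, whose value lies within the scatter of it, and the furthest is compound 1, which lies beyond the scatter on the lower side. Compound 4 `Cc1cccc(/C=C/C(=O)N2CCC=CS2(=O)=O)c1` is the next member of the series and has not yet been measured. The change from compound 3 to compound 4 is methyl in place of phenyl on an aromatic carbon. Going by the values given here, the one comparable step in the data is the exchange of substituents at that same place, a 1.2-fold lower number from compound 2 to compound 3 (0.08 log units; within the scatter), which was within the scatter. On that basis the substituent at this position has so far made no visible difference, and no step beyond the scatter is expected from compound 3 to compound 4 in this assay; the expected step is a 1.0-fold higher number from compound 3 to compound 4 (0.00 log units; within the scatter). Compound 4 is accordingly estimated at 20000 nM, with a range from 8000 nM to 50000 nM.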

Compound 4, concentration for 50% growth inhibition: 20700 nM
Compound 4: the middle estimate sits 1.0-fold (0.01 log units) below what was measured; the range from low to high includes it.
By their numbers in this assay, from the lowest: compound 1; then compounds 3, 4 and 2 (each within the scatter of the next).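

In this assay, the exchange of phenyl, with its six heavy atoms and its ring, for methyl, a single carbon with no ring, gives a 1.0-fold higher number from compound 3 to compound 4 (0.02 log units; within the scatter) and so leaves the read-out unmoved despite the loss of the whole ring. The exchange of methoxy for methyl at the same place gives a 1.1-fold lower number from compound 2 to compound 4 (0.06 log units; within the scatter) and is also without a visible effect. Compound 2, compound 3 and compound 4 thus form a set of three substituents on this aromatic carbon whose values all lie within the scatter of one another, which a single step could not show.

No accompanying data explain this flat response. From the compounds shown here alone, whether an amine, a carboxylic acid or a longer chain at this place would move the number in this assay remains open.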